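Cyclic amidine variant on the six-carbon linker series

A few compounds are considered here, and "the series" means these few. Any claim that something is new, unique, unknown or untested is made for them only; others in the source may bear on it.

Compound 1 `c1ccc(OCCCCCOc2cccc(-c3cc4cc(C5=NCCN5)ccc4o3)c2)cc1`: 2600 nM
Compound 2 `N=C(N)c1ccc2oc(-c3cccc(OCCCCCCOc4ccccc4)c3)cc2c1`: 3100 nM

In an ADME assay on L6 cells (Rattus norvegicus) for cytotoxicity, read by resazurin assay, with a stated time of 70 h (on this read-out lower numbers stand for stronger inhibition and higher numbers for weaker inhibition), compound 2 gives 3100 nM, and compound 1 gives 2600 nM, so the two sit within the scatter of each other. Compound 3 `c1ccc(OCCCCCCOc2cccc(-c3cc4cc(C5=NCCN5)ccc4o3)c2)cc1` is not yet measured. It differs from compound 2 by a group of 5 heavy atoms (3 carbon, 2 nitrogen; one five-membered non-aromatic ring with 2 hetero atoms) in place of a group of 3 heavy atoms (1 carbon, 2 nitrogen; no ring), on an aromatic carbon. Compound 1 already carries the same ring group on a shorter chain, and its number lies beside that of compound 2, so no step beyond the scatter is expected for compound 3. The estimate for compound 3 in this assay is 2700 nM, between 1300 nM and 5500 nM, a step of a 1.1-fold lower number from compound 2 to compound 3 (0.06 log units; within the scatter).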

Compound 3, half-maximal inhibitory concentration: 2500 nM
The estimate for compound 3 lay 1.1-fold (0.03 log units) above the measured number; the range from low to high includes it.
By their numbers in this assay, from the lowest: compounds 3, 1 and 2 (each within the scatter of the next).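

In this assay the five-membered ring group in place of the open group on the aromatic carbon gives a 1.2-fold lower number from compound 2 to compound 3 (0.09 log units; within the scatter) at equal chain length, a change in one place that the two earlier compounds did not offer. With the ring group held, phenoxymethyl in place of phenoxy on the saturated chain gives a 1.0-fold lower number from compound 1 to compound 3 (0.02 log units; within the scatter) and so neither change moves the number beyond the scatter. Nothing available accounts for either step.

Going by these compounds, whether an amine or a carboxylic acid on that aromatic carbon would move the number remains open. So does the effect of a longer chain than the one in compound 3.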